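Aminothiophene ketone piperazines: removing a chloro group

The source may report more compounds than this note shows. Statements on the series, on what has been measured and on what is new or still open speak of the compounds shown alone.

Measured so far in a functional assay on CHO cells with adenosine receptor A1 (Homo sapiens) as the target, read by cAMP accumulation and immunoassay, with a stated time of 6 min, tested at 0.01 uM; a higher number here means a weaker effect of the compound at the concentration tested, a lower number a stronger effect:
compound 1, `Nc1scc(CN2CCN(c3ccc(Cl)cc3F)CC2)c1C(=O)c1ccc(Cl)cc1`: -9.2%
compound 2, `Nc1scc(CN2CCN(c3ccc(C(F)(F)F)cc3)CC2)c1C(=O)c1cccc(C(F)(F)F)c1`: -12%

Compound 1 has the higher of the two numbers, but its gap to compound 2 lies within the scatter, so the two read alike: neither shows an effect at the concentration tested. Among the compounds with values here, no step between measured compounds is available.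

Compound 3, `Nc1scc(CN2CCN(c3ccccc3F)CC2)c1C(=O)c1ccc(Cl)cc1`, is the next compound to be run. It differs from compound 1 by hydrogen in place of chloro on an aromatic carbon. Within the data shown here, with both measured compounds sitting at essentially no activity and no measured step for guidance, nothing in the data points to a change beyond the scatter. The step of a number 1.2 percentage points higher from compound 1 to compound 3 (within the scatter) is expected to be small, of no set direction, and within the scatter. Compound 3 is expected to give -8% in this assay, most likely between -25% and 8%.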

Compound 3, a percentage reported as activity, at one concentration (the size of the read-out at that concentration, not a potency): 2.1%
Compound 3: the middle estimate sits 10.1 percentage points below what was measured, within the range that was stated.
By their numbers in this assay, from the lowest: compounds 2 and 1 (each within the scatter of the next); then compound 3.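

In this assay, the change from 4-chloro-2-fluorophenyl to 2-fluorophenyl gives a number 11.3 percentage points higher from compound 1 to compound 3 (beyond the scatter), a modest step towards a weaker effect at the concentration tested. Within the data shown here, this is the first single change that can be read, and it shows that the chloro group on this aromatic carbon, meta to the fluoro group and para to a large group, can shift the read-out beyond the scatter, though only this one pair supports that. No measurement at hand accounts for the step.

On these data alone, whether a methoxy group or an amine at the same carbon would move the number further, or in the opposite direction, remains open. Also open, as far as these compounds go, is whether removing the chloro group gives a similar step when the rest of the molecule differs.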